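Methoxy for fluoro on the methylsulfonyl-bearing core

This account rests on a few compounds, and the source may have more. Where it says the series, first, only, none or still open, it means among the compounds named here.

Measured so far:
compound 1 `COc1ccc(SC)c(NCC2=NCCN2)c1` — 107 nM
compound 2 `CS(=O)(=O)c1ccc(F)cc1NCC1=NCCN1` — 2630 nM

In an assay for binding affinity to Alpha-1D adrenergic receptor (Homo sapiens), read by radioligand binding (a lower number here means a stronger inhibitor, a higher number a weaker inhibitor), compound 2 gives the highest of the two numbers; compound 1 stands far lower, with the gap between them well beyond the scatter. Compound 3 `COc1ccc(S(C)(=O)=O)c(NCC2=NCCN2)c1` is not yet measured. It differs from compound 2 by methoxy in place of fluoro on an aromatic carbon. Compound 1 also carries the methoxy and gives 107 nM, but it differs from compound 3 elsewhere as well, so that comparison is only a loose guide. A moderate step downward is expected from compound 2 to compound 3, a 2.6-fold lower number from compound 2 to compound 3 (0.42 log units; beyond the scatter), possibly within the scatter. Compound 3 is estimated at 1000 nM, with a range from 300 nM to 3500 nM.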

Compound 3, inhibition constant: 7590 nM
The estimate for compound 3 lay 7.6-fold (0.88 log units) below the measured number; measured number above the stated range.
By their numbers in this assay, from the lowest: compound 1; then compound 2; then compound 3.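

In this assay, methoxy in place of fluoro para to the methylsulfonyl group does not lower the number (a 2.9-fold higher number from compound 2 to compound 3 (0.46 log units; beyond the scatter)), so the methoxy alone does not give compound 1 its low value. Methylsulfonyl in place of methylsulfanyl gives a much greater change (a 71-fold higher number from compound 1 to compound 3 (1.85 log units; beyond the scatter)), which makes that group the larger point of difference among these compounds. Nothing at hand gives a reason for either step.

Still open, as far as these compounds go, is how an amine or a longer alkoxy chain would read at the fluoro position. Also open, from the compounds shown here alone, is whether methoxy in place of fluoro gives a similar step when methylsulfanyl replaces methylsulfonyl.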